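Replacing Propyl with Pyridin-3-yl on the Amine Arm

This account rests on a few compounds, and the source may have more. Where it says the series, first, only, none or still open, it means among the compounds named here.

Compound 1 `CCCCNc1nc(C(F)(F)F)ccc1CNC(=O)C(C)c1ccc(NS(C)(=O)=O)c(F)c1` is the reference point of this short series. Within the data shown here, in a functional assay on CHO-K1 cells for antagonist activity at transient receptor potential cation channel subfamily V member 1 (Homo sapiens), read by FLIPR (on this read-out higher numbers stand for weaker inhibition and lower numbers for stronger inhibition), compound 1 gives 9.1 nM, the lowest of the three numbers measured so far. Compound 2 `Cc1ccc(Cl)cc1Nc1nc(C(F)(F)F)ccc1CNC(=O)C(C)c1ccc(NS(C)(=O)=O)c(F)c1` gives 14 nM, and compound 3 `CC(C(=O)NCc1ccc(C(F)(F)F)nc1NCc1ccc(Cl)cc1)c1ccc(NS(C)(=O)=O)c(F)c1` gives 65.7 nM. The step of a 1.5-fold higher number from compound 1 to compound 2 (0.19 log units; within the scatter) stays within the scatter, whereas a 7.2-fold higher number from compound 1 to compound 3 (0.86 log units; beyond the scatter) and a 4.7-fold higher number from compound 2 to compound 3 (0.67 log units; beyond the scatter) both go beyond it.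

Compound 4 `CC(C(=O)NCc1ccc(C(F)(F)F)nc1NCc1cccnc1)c1ccc(NS(C)(=O)=O)c(F)c1` has not yet been measured. It differs from compound 1 by pyridin-3-yl in place of propyl on a saturated chain carbon bound to a nitrogen on an aromatic ring. The step that bears most directly on this change is a 7.2-fold higher number from compound 1 to compound 3 (0.86 log units; beyond the scatter), where an aromatic ring likewise entered in place of propyl on the saturated chain carbon bound to a nitrogen on an aromatic ring. The step of a 4.7-fold higher number from compound 2 to compound 3 (0.67 log units; beyond the scatter) also ended at that same arrangement and pointed the same way. Both steps were modest and beyond the scatter, so compound 4 is expected to return a higher number than compound 1 in this assay, by about a 7.7-fold higher number from compound 1 to compound 4 (0.89 log units; beyond the scatter). The estimate for compound 4 is 70 nM, with a range from 22 nM to 220 nM.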

Compound 4, inhibition constant: "not active" (no number reported)
Nothing numeric was reported for compound 4; the estimate stays without a comparison.
By their numbers in this assay, from the lowest: compounds 1 and 2 (each within the scatter of the next); then compound 3.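

In this assay, among these compounds, compound 4 was reported as not active, without a number, and no step from compound 1, compound 2 or compound 3 to compound 4 can be read. Nothing shown here bears on this result. The compounds shown leave open how far pyridin-3-yl in compound 4 stands from 4-chlorophenyl in compound 3.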